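The compounds below may be only part of what the source reports. "The series", "measured", "known", "first", "only" and "open" are said of these compounds alone.

Compound 1 `O=C(CN(c1ncnc2c1ncn2C1CCCCO1)C1CC1)N[C@@H](CCC(=O)OCc1ccccc1)C(=O)OCc1ccccc1` gives 34.7% in a functional assay on the whole organism (Tail, strain ICR) with Mus musculus as the target, in the tail flick test, with a stated time of 60 min, at a dose of 25 umol/kg by the oral route (on this read-out higher numbers stand for a stronger effect at the one dose given and lower numbers for a weaker effect), the lowest of the three measured numbers. Compound 2 `O=C(CN(c1nc(Cl)nc2[nH]cnc12)C1CC1)N[C@@H](CCC(=O)OCc1ccccc1)C(=O)OCc1ccccc1` gives 53.7% in this assay, and compound 3 `NCCCC[C@H](NC(=O)CN(c1nc(Cl)nc2[nH]cnc12)C1CC1)C(=O)O` gives 53.8% in this assay; both lie beyond the scatter above compound 1, while their own two values stand within the scatter of each other. Compound 4 `N=C(N)NCCC[C@H](NC(=O)CN(c1ncnc2c1ncn2C1CCCCO1)C1CC1)C(=O)OCc1ccccc1` has not yet been measured in this assay. It differs from compound 1 as follows: a group of 5 heavy atoms (2 carbon, 3 nitrogen; no ring) in place of a group of 10 heavy atoms (8 carbon, 2 oxygen; one six-membered aromatic ring of carbon only), on a saturated chain carbon, three bonds along the chain from an amide-type nitrogen and a carbonyl carbon. Going by the values given here, no measured pair of compounds shows a change of this kind, so its direction can only be guessed. The step of a number 5.3 percentage points higher from compound 1 to compound 4 (within the scatter) is expected to be small, upward if anything, and not beyond the scatter. Compound 4 is therefore estimated to give 40% in this assay, within a range of 20% to 60%.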

Compound 4, a percentage reported as activity, at one dose (the size of the read-out at that dose, not a potency): 52.4%
Beside the measured number, compound 4's estimate is 12.4 percentage points below it, within the range that was stated.
By their numbers in this assay, from the lowest: compound 1; then compounds 4, 2 and 3 (each within the scatter of the next).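

In this assay, going by these compounds alone, exchanging the benzyloxycarbonyl on this saturated chain carbon for the ringless group of 5 heavy atoms gives a number 17.7 percentage points higher from compound 1 to compound 4 (beyond the scatter) and is the first change at this position that can be read. On this core, the benzyloxycarbonyl and its aromatic ring are therefore not needed for the effect at this dose. Nothing measured here explains the rise. As far as these compounds go, it remains open whether the gain comes from losing the benzyloxycarbonyl or from the group that enters. A hydroxyl group or a methyl ester at this place could separate the two.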